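The source may hold more compounds than are shown below. What is called first, only, known or untested is meant among the compounds shown, and "the series" means these compounds.

Compound 1 `O=C(O)CCc1cccc2c1B(O)OC2` — in a functional assay on HCT-116 cells (Homo sapiens) for antiproliferative activity, read by MTT assay, with a stated time of 72 h (a lower number here means a stronger inhibitor, a higher number a weaker inhibitor), compound 1 gives only a limit, > 100000 nM.
Compound 2 `O=C(CCc1cccc2c1B(O)OC2)Nc1ccc(Cl)cc1` — compound 2 gives 12000 nM.
Compound 3 `CC(C)(C)OC(=O)NCc1ccc(NC(=O)CCc2cccc3c2B(O)OC3)cc1` — compound 3 gives 2300 nM.

Going by the values given here, compound 2 stands highest of the two numbers so far in this assay; its nearest neighbour is compound 3, reached by a 5.2-fold lower number from compound 2 to compound 3 (0.72 log units; beyond the scatter), a modest step that lies beyond the scatter. The value of compound 1 is a limit of the assay, not a number: the limit of > 100000 nM in this assay, at which 1 of the 3 values shown sits.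

Compound 4 `CCOC(=O)c1ccc(NC(=O)CCc2cccc3c2B(O)OC3)cc1` is not yet measured in this assay. Against compound 2 the change is ethoxycarbonyl in place of chloro on an aromatic carbon. Among the compounds with values here, the single measured step that bears on this is the one at the same aromatic carbon, a 5.2-fold lower number from compound 2 to compound 3 (0.72 log units; beyond the scatter), where a larger group replacing chloro went with a modest gain. Within the data shown here, the ethoxycarbonyl group is smaller than the group that enters in compound 3, and there is no second example to show whether a gain follows any replacement of chloro here or depends on the group chosen. A step in the same direction, but of smaller size, is therefore expected for compound 4, a 2.0-fold lower number from compound 2 to compound 4 (0.30 log units; within the scatter). Compound 4 is estimated at 6000 nM in this assay, within 2000 nM to 20000 nM.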

Compound 4, half-maximal inhibitory concentration: > 100000 nM
Compound 4 was reported as a limit (the forecaster's own chance of this, stated with the estimate: 5%); at least 16-fold (1.22 log units) between middle value and limit.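

In this assay, replacing chloro at this aromatic carbon, para to a large group, does not in itself go with a gain, since ethoxycarbonyl gives an at least 8.3-fold higher number from compound 2 to compound 4 (0.92 log units; beyond the scatter), which runs opposite to the earlier 5.2-fold lower number from compound 2 to compound 3 (0.72 log units; beyond the scatter). The outcome therefore follows the group that enters rather than the loss of chloro, and the two larger groups are far apart, with an at least 43-fold higher number from compound 3 to compound 4 (1.63 log units; beyond the scatter); size alone does not order the series, as ethoxycarbonyl, larger than chloro and smaller than ((tert-butoxycarbonyl)amino)methyl, sits on the weak side of both. Compound 4 gives a limit and not a number, the same limit as compound 1: the limit of > 100000 nM in this assay, at which 2 of the 4 values shown sit.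

The compounds shown leave open which part of ((tert-butoxycarbonyl)amino)methyl goes with the gain, and whether the carbonyl or the ethyl part of ethoxycarbonyl goes with the loss. A free aminomethyl, a carboxylic acid or a methyl ketone at the same aromatic carbon would help separate these readings.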